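This account rests on a few compounds, and the source may have more. Where it says the series, first, only, none or still open, it means among the compounds named here.

Compound 1, with the structure `COc1cc(/C=C/C(=O)c2sc(Nc3ccc(C)cc3)nc2C)cc(OC)c1OC`, gives in a functional assay on Bel-7402 cells (Homo sapiens) for cytotoxicity, read by MTT assay (on this read-out higher numbers stand for weaker inhibition and lower numbers for stronger inhibition), a value of > 25000 nM, which is a limit of the assay rather than a number. Compound 2, the structure `COc1cc(/C=C/C(=O)c2sc(Nc3ccccc3C)nc2C)cc(OC)c1OC`, differs from compound 1 by 2-methylphenyl in place of 4-methylphenyl on a nitrogen on an aromatic ring. In this assay compound 2 gives a value of 10300 nM. The step recorded is an at least 2.4-fold lower number from compound 1 to compound 2 (0.38 log units; beyond the scatter).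

Compound 3, the structure `Cc1ccc(Nc2nc(C)c(C(=O)/C=C/c3ccccc3Cl)s2)cc1`, gives in this assay a value of > 25000 nM, again a limit of the assay. How the core of compound 3 differs from the core of compound 1 is not broken down here.

Compound 4, the structure `Cc1ccccc1Nc1nc(C)c(C(=O)/C=C/c2ccccc2Cl)s1`, has not yet been measured in this assay. It differs from compound 3 by 2-methylphenyl in place of 4-methylphenyl on a nitrogen on an aromatic ring, the same change that separated compound 1 and compound 2. For compound 4 the expected step is an at least 1.6-fold lower number from compound 3 to compound 4 (0.22 log units; that floor lies within the scatter), resting on the earlier step of an at least 2.4-fold lower number from compound 1 to compound 2 (0.38 log units; beyond the scatter), though the starting point of compound 3 is only known as the limit of > 25000 nM in this assay, at which 2 of the 3 values shown sit. Compound 4 is therefore expected to give about 15000 nM, estimated between 6000 nM and 40000 nM.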

Compound 4, half-maximal inhibitory concentration: > 25000 nM
Compound 4: a limit, no number (the forecaster's own chance of this, stated with the estimate: 40%); middle value at least 1.6-fold (0.22 log units) away from the limit.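

In this assay compound 4 gives > 25000 nM, a limit of the assay and not a number. For the compounds shown here, with compound 3 also at a limit, no step from compound 3 to compound 4 can be read: the limit of > 25000 nM in this assay, at which 3 of the 4 values shown sit. The compounds shown leave open whether 2-methylphenyl in place of 4-methylphenyl lowers the number on the core of compound 3 as it did on the core of compound 1.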